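Nitrile to hydroxymethyl on a side chain: what to expect

This account rests on a few compounds, and the source may have more. Where it says the series, first, only, none or still open, it means among the compounds named here.

Compound 1 `CCCn1c(=O)n(CCC(=O)O)c(=O)c2[nH]cnc21` – in an assay on Cerebral cortex for binding affinity to adenosine receptor A1 (Cavia porcellus), read by radioligand binding (on this read-out lower numbers stand for stronger inhibition and higher numbers for weaker inhibition), compound 1 reaches only the assay limit of > 200000 nM.
Compound 2 `CCCn1c(=O)n(CCCO)c(=O)c2[nH]cnc21` – compound 2 gives 12000 nM.
Compound 3 `CCCn1c(=O)n(C)c(=O)c2c1ncn2CC#N` – compound 3 gives 6600 nM.

Of the two compounds with a number, compound 3 holds the lower one, but its gap to compound 2 lies within the scatter, so the two are not separable. Compound 4 `CCCn1c(=O)n(C)c(=O)c2c1ncn2CCO` differs from compound 3 by one change: hydroxymethyl in place of cyano on a saturated chain carbon bound to an aromatic nitrogen. For the measured compounds named here, the only measured step that touches a hydroxymethyl is an at least 16-fold lower number from compound 1 to compound 2 (1.22 log units; beyond the scatter), yet it exchanges a carboxy group at a different place on the structure, so it gives little direct guidance. Going by the values given here, with no closer precedent, the expected step is small: compound 4 is estimated at 5000 nM (range 1500 nM to 20000 nM), which would mean a 1.3-fold lower number from compound 3 to compound 4 (0.12 log units; within the scatter).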

Compound 4, inhibition constant: 41400 nM
Compound 4: middle estimate off by 8.3-fold (0.92 log units), on the low side; the measured number lies above the stated range.
By their numbers in this assay, from the lowest: compounds 3 and 2 (each within the scatter of the next); then compound 4. At a limit, above all of these: compound 1.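

Cyano and hydroxymethyl have the same count of heavy atoms and neither carries a net charge, yet on this saturated chain carbon bound to an aromatic nitrogen the exchange is not neutral: in this assay it gives a 6.3-fold higher number from compound 3 to compound 4 (0.80 log units; beyond the scatter). For the compounds shown here, the earlier compounds offered no step at this place, so this is the first direct reading of it. Nothing measured here explains the loss. From the compounds shown here alone, how an amine or a carboxylic acid would fare at this place stays open, and so does the effect of a longer chain.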